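This account rests on a few compounds, and the source may have more. Where it says the series, first, only, none or still open, it means among the compounds named here.

Measured compounds:
compound 1 `COc1ccc2c(O[C@H]3C[C@H]4C(=O)N(C)CCCC/C=C/[C@@H]5C[C@@]5(C(=O)NS(=O)(=O)C5CC5)NC(=O)N4C3)cc(-c3nc(C4CC4)cs3)nc2c1Cl` — 31300 nM
compound 2 `COc1ccc2c(O[C@H]3C[C@H]4C(=O)N(C)CCCC/C=C/[C@@H]5C[C@@]5(C(=O)NS(=O)(=O)C5(C)CC5)NC(=O)N4C3)cc(-c3nc(C4CCC4)cs3)nc2c1Cl` — 75000 nM

In an ADME assay on Huh-7 cells (Homo sapiens) for cytotoxicity, read by colorimetric assay (a lower number here means that less compound is tolerated, a higher number that more compound is tolerated), compound 2 gives 75000 nM, the higher of the two numbers; compound 1 gives 31300 nM, a gap beyond the scatter. Among the measured compounds shown here, these two differ in more than one place, so no single step is drawn between them. Compound 3 `COc1ccc2c(O[C@H]3C[C@H]4C(=O)N(C)CCCC/C=C/[C@@H]5C[C@@]5(C(=O)NS(=O)(=O)C5(C)CC5)NC(=O)N4C3)cc(-c3csc(C(C)C)n3)nc2c1Cl` is not yet measured and carries 2-isopropyl-1,3-thiazol-4-yl in place of 4-cyclobutyl-1,3-thiazol-2-yl on an aromatic carbon. Little movement is expected from this exchange in this assay, with a step of about a 1.3-fold lower number from compound 2 to compound 3 (0.10 log units; within the scatter) that may well stay within the scatter. Compound 3 is estimated at 60000 nM, with a range from 25000 nM to 150000 nM.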

Compound 3, half-maximal cytotoxic concentration: 30200 nM
Estimate against measurement, compound 3: 2.0-fold (0.30 log units) above; measured number inside the range.
By their numbers in this assay, from the lowest: compounds 3 and 1 (each within the scatter of the next); then compound 2.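

In this assay, this position on an aromatic carbon next to the ring nitrogen is shown to respond to the thiazole substituent: 2-isopropyl-1,3-thiazol-4-yl in place of 4-cyclobutyl-1,3-thiazol-2-yl gives a 2.5-fold lower number from compound 2 to compound 3 (0.40 log units; beyond the scatter). This is the only single-place step shown, and it is modest. No measurement shown bears on what underlies it.

As far as these compounds go, the exchange alters both the thiazole attachment and the substituent, so their separate contributions remain open. Also open, from the compounds shown here alone, is how an amino group on the thiazole would read in this position.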